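Difluorophenyl placement on the piperazine aryl ring

A few compounds are considered here, and "the series" means these few. Any claim that something is new, unique, unknown or untested is made for them only; others in the source may bear on it.

Going by the values given here, compound 2 `Nc1scc(CN2CCN(c3ccc(F)cc3F)CC2)c1C(=O)c1ccc(Cl)cc1` is one of two compounds measured so far in a functional assay on CHO cells with adenosine receptor A1 (Homo sapiens) as the target, read by cAMP accumulation and immunoassay, with a stated time of 6 min, tested at 0.1 uM; a lower number here means a stronger effect, a higher number a weaker effect of the compound at the concentration tested. In this assay compound 2 gives -17%, and compound 1 `Nc1scc(CN2CCN(c3ccccc3C(F)(F)F)CC2)c1C(=O)c1ccc(Cl)cc1` gives -7.5%; the two numbers lie within the scatter of each other, so neither is set apart. Among the compounds with values here, the only step measured, a number 9.5 percentage points lower from compound 1 to compound 2 (within the scatter), exchanges one aryl group on the ring nitrogen for another and stays within the scatter. Compound 3 `Nc1scc(CN2CCN(c3cc(F)cc(F)c3)CC2)c1C(=O)c1ccc(Cl)cc1` differs from compound 2 by 3,5-difluorophenyl in place of 2,4-difluorophenyl on an amine nitrogen in a ring. Within the data shown here, no measured step shares this change, and the one step that also alters the aryl group on that ring nitrogen did not move beyond the scatter, so no step beyond the scatter is expected in this assay for compound 3 either; the step of a number 5 percentage points higher from compound 2 to compound 3 (within the scatter) is estimated to be small. The estimate for compound 3 in this assay is -12%, expected to fall between -30% and 8%.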

Compound 3, a percentage reported as activity, at one concentration (the size of the read-out at that concentration, not a potency): -5%
Estimate against measurement, compound 3: 7 percentage points below, and the stated range covers the measured number.
By their numbers in this assay, from the lowest: compounds 2, 1 and 3 (each within the scatter of the next, the first and the last beyond it).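

In this assay, going by these compounds alone, a number 12 percentage points higher from compound 2 to compound 3 (beyond the scatter) is the only step among the three compounds that lies beyond the scatter, and it is modest; the two groups have the same atoms, joined differently, so the arrangement of the two fluorines on this aryl group alone is enough to separate compound 2 from compound 3. By contrast, a number 2.5 percentage points higher from compound 1 to compound 3 (within the scatter) stays within the scatter, so 3,5-difluorophenyl is not set apart from 2-(trifluoromethyl)phenyl on this ring nitrogen. Nothing available explains the difference between the two difluorophenyl groups.

As far as these compounds go, it remains open whether an unsubstituted phenyl, a 4-fluorophenyl or a 4-methoxyphenyl on the same nitrogen would fall with compound 2 or with compound 3. With so few aryl groups compared, no trend across this position can yet be stated.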